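Chlorotrifluoromethylphenyl ureas: swapping ring substitution on a biaryl core

This account rests on a few compounds, and the source may have more. Where it says the series, first, only, none or still open, it means among the compounds named here.

Measured compounds:
Compound 1 `CC(NC(=O)/C=C/c1ccc(NC(=O)Nc2ccc(Cl)c(C(F)(F)F)c2)cc1)c1ccccc1`: 3130 nM
Compound 2 `CC(NC(=O)c1ccc(-c2ccc(NC(=O)Nc3cc(C(F)(F)F)ccc3Cl)cc2)cc1)c1ccccc1`: 17700 nM
Compound 3 `CC(NC(=O)/C=C/c1ccc(NC(=O)Nc2cc(C(F)(F)F)ccc2Cl)cc1)c1ccccc1`: 1890 nM

Of the compounds shown here, three have been tested in a functional assay on MX1 cells (Homo sapiens) for inhibition, read by MTT assay, with a stated time of 120 h; on this read-out lower numbers stand for stronger inhibition and higher numbers for weaker inhibition. Compound 3 gives 1890 nM in this assay, and compound 1 gives 3130 nM. The two differ only by 4-chloro-3-(trifluoromethyl)phenyl in place of 2-chloro-5-(trifluoromethyl)phenyl on an amide-type nitrogen, and the step is a 1.7-fold higher number from compound 3 to compound 1 (0.22 log units; within the scatter), so the two values are indistinguishable on this read-out. Compound 2 carries a biaryl amide core instead of the acrylamide core of compound 3. In this assay compound 2 gives 17700 nM; the difference between the two cores is not broken down here, and its value stands well apart from those of compound 1 and compound 3.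

Compound 4 `CC(NC(=O)c1ccc(-c2ccc(NC(=O)Nc3ccc(Cl)c(C(F)(F)F)c3)cc2)cc1)c1ccccc1` has not yet been measured. It differs from compound 2 by 4-chloro-3-(trifluoromethyl)phenyl in place of 2-chloro-5-(trifluoromethyl)phenyl on an amide-type nitrogen, which is the same change as that from compound 3 to compound 1, made at a place described in identical words. Because a 1.7-fold higher number from compound 3 to compound 1 (0.22 log units; within the scatter) stayed within the scatter, the step from compound 2 to compound 4 is also expected to be small, about a 1.4-fold higher number from compound 2 to compound 4 (0.15 log units; within the scatter) in this assay. Compound 4 is therefore expected to give 25000 nM, most likely between 8000 nM and 70000 nM.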

Compound 4, half-maximal inhibitory concentration: 4630 nM
Estimate against measurement, compound 4: 5.4-fold (0.73 log units) above; measured number below the stated range.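

In this assay, the exchange of 2-chloro-5-(trifluoromethyl)phenyl for 4-chloro-3-(trifluoromethyl)phenyl on an amide-type nitrogen amounts to a 3.8-fold lower number from compound 2 to compound 4 (0.58 log units; beyond the scatter). Set beside the same exchange on the core of compound 3, this step shows that the change did not carry over unaltered from one core to the other: the same change on two cores in this assay, a 1.7-fold higher number (0.22 log units; within the scatter) from compound 3 to compound 1 and a 3.8-fold lower number (0.58 log units; beyond the scatter) from compound 2 to compound 4, 6.3-fold (0.80 log units) apart, beyond the scatter of two such steps. Going by these compounds alone, with only one pair on each core, the comparison shows that the size and direction of the step are not the same on these two cores, but it does not show why they differ or how the exchange would behave on any further core.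

The compounds shown leave open whether the two cores would also part ways if a nitrile or a methoxy group took the place of the chlorine. They also leave open whether the gap between the steps would persist with a morpholine in place of the phenylethyl group on the amide.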